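Phenol series: aryl swap on the triazole

A few compounds are considered here, and "the series" means these few. Any claim that something is new, unique, unknown or untested is made for them only; others in the source may bear on it.

Measured so far in a functional assay on SMMC-7721 cells (Homo sapiens) for cytotoxicity, read by MTT assay, with a stated time of 4 days; on this read-out lower numbers stand for stronger inhibition and higher numbers for weaker inhibition:
compound 1 `C=C1C[C@]23C[C@@]1(O)CC[C@H]2c1ccc(OS(=O)(=O)c2ccc(C)cc2)c(C)c1[C@@H]3Cn1cc(-c2ccc(Cl)cc2)nn1` — > 20000 nM
compound 2 `C=C1C(=O)[C@]23C[C@@]1(O)CC[C@H]2c1ccc(OS(=O)(=O)c2ccc(C)cc2)c(C)c1[C@@H]3Cn1cc(-c2ccccn2)nn1` — 2830 nM
compound 3 `C=C1C(=O)[C@]23C[C@@]1(O)CC[C@H]2c1ccc(O)c(C)c1[C@@H]3Cn1cc(-c2ccccn2)nn1` — 1270 nM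

The value of compound 1 is a limit of this assay, not a number (the limit of > 20000 nM in this assay, at which 1 of the 3 values shown sits). Among the two numbers, compound 3 gives the lower one; the step of a 2.2-fold lower number from compound 2 to compound 3 (0.35 log units; beyond the scatter) is modest. Compound 4 `C=C1C(=O)[C@]23C[C@@]1(O)CC[C@H]2c1ccc(O)c(C)c1[C@@H]3Cn1cc(-c2ccc(Br)cc2)nn1` differs from compound 3 by 4-bromophenyl in place of pyridin-2-yl on an aromatic carbon. Among the measured compounds shown here, no measured pair differs in this place alone, so no step bears on it directly; compound 1 carries a halogenated phenyl on the same ring but differs from compound 3 in more than one place, and only its limit is known. The expected step of a 2.8-fold higher number from compound 3 to compound 4 (0.44 log units; beyond the scatter) is therefore uncertain and leans toward a higher number. Compound 4 is estimated at 3500 nM, within 900 nM to 15000 nM.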

Compound 4, half-maximal inhibitory concentration: 1300 nM
The estimate for compound 4 lay 2.7-fold (0.43 log units) above the measured number; the measured number falls inside the stated range.
By their numbers in this assay, from the lowest: compounds 3 and 4 (each within the scatter of the next); then compound 2. At a limit, above all of these: compound 1.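

With the shared core otherwise unchanged, 4-bromophenyl in place of pyridin-2-yl gives a 1.0-fold higher number from compound 3 to compound 4 (0.01 log units; within the scatter). At this aromatic carbon, the ring nitrogen of pyridin-2-yl is therefore not needed to hold the level of compound 3, at least for this pair. The data shown give no reason for this match.

From the compounds shown here alone, it remains open whether an amine, a carboxylic acid or a longer alkyl chain at this carbon would hold that level. Going by these compounds, the effect of 4-bromophenyl with (4-methylphenyl)sulfonyl on the oxygen also remains open.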